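Three Esters at the Toxicity Ceiling and an Amidine

The compounds below may be only part of what the source reports. "The series", "measured", "known", "first", "only" and "open" are said of these compounds alone.

Compound 1 `CC(=O)OCc1cccc2c1CCOC2=O`: in an ADME assay on HepG2 2.2.15 cells (Homo sapiens) for cytotoxicity, read by MTT assay, with a stated time of 72 h (on this read-out higher numbers stand for lower toxicity in this test and lower numbers for higher toxicity in this test), compound 1 reaches only the assay limit of > 2430000 nM.
Compound 2 `O=C1OCCc2c(COC(=O)C3CCCCC3)cccc21`: in this assay compound 2 likewise reaches only a limit, > 1840000 nM.
Compound 3 `O=C(OCc1cccc2c1CCOC2=O)c1ccco1`: in this assay compound 3 too reaches only a limit, > 2350000 nM.

Compound 1 therefore stands at a limit, as do both other measured compounds, so none of the three can be placed in order. The steps a step that the two limits leave unreadable from compound 1 to compound 2, a step that the two limits leave unreadable from compound 1 to compound 3 and a step that the two limits leave unreadable from compound 2 to compound 3 are for that reason unreadable. Compound 4 `N=C(N)c1cccc2c1CCOC2=O` differs from compound 1 by a group of 3 heavy atoms (1 carbon, 2 nitrogen; no ring) in place of a group of 5 heavy atoms (3 carbon, 2 oxygen; no ring), on an aromatic carbon. Among the measured compounds shown here, no measured step touches this position, so none gives a readable size. Because every measured compound sits at a limit (the limit of > 1840000 nM in this assay, at which 1 of the 3 values shown sits), (the limit of > 2350000 nM in this assay, at which 1 of the 3 values shown sits), (the limit of > 2430000 nM in this assay, at which 1 of the 3 values shown sits), compound 4 is expected to show no change in toxicity beyond the scatter, a step of an at least 1.2-fold lower number from compound 1 to compound 4 (0.08 log units; that floor lies within the scatter), most likely again a limit. Compound 4 is estimated at 2000000 nM, between 400000 nM and 5000000 nM.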

Compound 4, half-maximal cytotoxic concentration: 2050000 nM
For compound 4 the middle estimate is 1.0-fold (0.01 log units) below the measured one, and the stated range covers the measured number.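

In this assay, among the compounds shown here, compound 4 gives 2050000 nM, the first true number in this set rather than a limit. For the compounds shown here, putting the amidine on this aromatic carbon in place of acetoxymethyl gives an at least 1.1-fold lower number from compound 1 to compound 4 (0.07 log units; that floor lies within the scatter), so this is the first change at this position, and it shows no rise in toxicity beyond the scatter. Compound 1 sits at a limit, so this floor does not fix the real size of the step: the limit of > 2430000 nM in this assay, at which 1 of the 4 values shown sits.

From the compounds shown here alone, how an aminomethyl group or a carboxylic acid on this aromatic carbon would read in this assay stays open. So does whether any group here gives a clearly lower number.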